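Pyrazolyl Groups on a Ring Nitrogen: Estimating Compound 4

This account rests on a few compounds, and the source may have more. Where it says the series, first, only, none or still open, it means among the compounds named here.

Three compounds have been measured in an assay on isolated protein for inhibition of Leucine-rich repeat serine/threonine-protein kinase 2 (Homo sapiens), read by TR-FRET and LanthaScreen, with stated times of 50 min and 30 min, in the presence of a further agent that is not named here; on this read-out lower numbers stand for stronger inhibition and higher numbers for weaker inhibition:
compound 1 `C[C@@H]1CCCN1c1c(C#N)c2c(N)nc(Nc3cn(C)nc3Cl)nc2n1C`, 34 nM
compound 2 `Cc1c(Nc2nc(N)c3c(C#N)c(N4CCC[C@H]4C)n(C)c3n2)cnn1C1COC1`, 47 nM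
compound 3 `C[C@@H]1CCCN1c1c(C#N)c2c(N)nc(N)nc2n1C`, 248 nM

Compound 3 carries only hydrogen on the nitrogen on the aromatic ring and stands highest of the three numbers. Two steps end at it, a 7.3-fold higher number from compound 1 to compound 3 (0.86 log units; beyond the scatter) and a 5.3-fold higher number from compound 2 to compound 3 (0.72 log units; beyond the scatter), both beyond the scatter, while the two substituted compounds sit within the scatter of each other, a 1.4-fold higher number from compound 1 to compound 2 (0.14 log units; within the scatter).

Compound 4 `C[C@@H]1CCCN1c1c(C#N)c2c(N)nc(Nc3cnn(C)c3)nc2n1C` differs from compound 3 by 1-methyl-1H-pyrazol-4-yl in place of hydrogen on a nitrogen on an aromatic ring. The two measured steps that bear on this change both show that placing a pyrazolyl group on that nitrogen lowers the number in this assay by a modest but clear amount, and the group entering in compound 4 is a pyrazolyl ring like those in compound 1 and compound 2. Compound 4 is therefore expected to show a step of a 5.0-fold lower number from compound 3 to compound 4 (0.70 log units; beyond the scatter), in the lowering direction, beyond the scatter. The estimate for compound 4 in this assay is 50 nM, with a range from 20 nM to 130 nM.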

Compound 4, half-maximal inhibitory concentration: 6 nM
For compound 4 the middle estimate is 8.3-fold (0.92 log units) above the measured one; measured number outside the range, below it.
By their numbers in this assay, from the lowest: compound 4; then compounds 1 and 2 (each within the scatter of the next); then compound 3.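

In this assay, the step on this nitrogen is large (a 41-fold lower number from compound 3 to compound 4 (1.62 log units; beyond the scatter)), so the effect of a pyrazolyl group here depends strongly on what that ring carries. Compound 1 and compound 2 had stood within the scatter of each other, yet the ring bearing only the methyl group separates from both, by a modest step from the oxetanyl-bearing ring (a 7.8-fold lower number from compound 2 to compound 4 (0.89 log units; beyond the scatter)) and by a modest step on removal of the chloro group, with hydrogen in its place on an aromatic carbon (a 5.7-fold lower number from compound 1 to compound 4 (0.75 log units; beyond the scatter)). Nothing shown accounts for the size of these steps.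

The compounds shown leave open whether an ethyl group on the pyrazole nitrogen would hold the number of compound 4. They also leave open whether fluoro in place of the chloro group, or a phenyl ring in place of the pyrazole, would do so.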